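Notes on a chloro-to-hydrogen step in a small series

The source may report more compounds than this note shows. Statements on the series, on what has been measured and on what is new or still open speak of the compounds shown alone.

Measured so far:
- compound 1, `CCCNNC(=O)c1cnc(NCc2cc(Cl)ccc2Cl)nc1`: 83%
- compound 2, `CCCCNNC(=O)c1cnc(NCc2ccccc2)nc1`: 94%

Both were run in an assay on isolated protein for inhibition of histone deacetylase 8 (Homo sapiens), read by fluorescence, with a stated time of 5 min, tested at 10 uM; a higher number here means a stronger effect of the compound at the concentration tested, a lower number a weaker effect. Compound 1 gives 83% there, the lower of the two numbers; compound 2 gives 94%, and the gap between the two lies beyond the usual scatter. Among the measured compounds shown here, the two compounds differ in more than one place, so no single step between them can be read off.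

The next compound, compound 3, is `CCCNNC(=O)c1cnc(NCc2ccccc2Cl)nc1`. Relative to compound 1 the change is hydrogen in place of chloro on an aromatic carbon; the propyl chain and the rest of the shared core are kept. Without a measured step of this kind, the expectation rests on the two numbers above: compound 2, which carries no chloro group at all, sits higher than compound 1 in this assay, yet the two also differ in chain length, so the dechlorination alone cannot be credited with that gap. A small step is expected, if any, leaning upward but likely within the scatter.

Compound 3 is estimated at 86% in this assay, with a range of 72% to 96%. That corresponds to an expected step of a number 3 percentage points higher from compound 1 to compound 3 (within the scatter).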

Compound 3, a percentage reported as inhibition, at one concentration (the size of the read-out at that concentration, not a potency): 87%
Compound 3: the middle estimate sits 1 percentage points below what was measured; low and high end bracket the measured number.
By their numbers in this assay, from the lowest: compounds 1, 3 and 2 (each within the scatter of the next, the first and the last beyond it).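

Among the compounds shown here, the first single-place step, hydrogen in place of chloro on an aromatic carbon, meta to a large group and para to a chloro group, reads in this assay as a number 4 percentage points higher from compound 1 to compound 3 (within the scatter), so compound 1 and compound 3 cannot be told apart here. At this position, the chloro group is therefore not required for a high read-out at the concentration tested, although that read-out is a size at one concentration and not a potency, so any difference in potency stays hidden. No supporting information bears on the reason for this result.

Still open, going by these compounds, is whether the remaining chloro group can also give way to hydrogen with the propyl chain kept, which would separate the contribution of the chloro groups from that of the chain. Also open, on these data alone, is what a fluoro, methoxy or trifluoromethyl group would give on the aromatic carbon that now carries hydrogen, and what a pentyl chain would give in place of the propyl chain.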